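The source may report more compounds than this note shows. Statements on the series, on what has been measured and on what is new or still open speak of the compounds shown alone.

Compound 3 `NC(=O)Cc1cc(=O)oc2cc(OCc3ccccc3)ccc12` stands at the lowest number of the three measured compounds in an assay (strain Wistar) for inhibition of Amine oxidase [flavin-containing] A (Rattus norvegicus) (a lower number here means a stronger inhibitor, a higher number a weaker inhibitor), giving 8000 nM; compound 2 `NC(=O)[C@@H]1CCCN1Cc1cc(=O)oc2cc(OCc3ccccc3)ccc12` gives 35000 nM and compound 1 `C[C@H](Nc1cc(=O)oc2cc(OCc3ccccc3)ccc12)C(N)=O` gives 100000 nM. Compound 4 `CC(C(N)=O)c1cc(=O)oc2cc(OCc3ccccc3)ccc12` differs from compound 3 by methyl in place of hydrogen on a saturated chain carbon bound to an aromatic carbon and a carbonyl carbon. Within the data shown here, no measured step isolates this change. The closest is a 13-fold lower number from compound 1 to compound 3 (1.10 log units; beyond the scatter), in which the methyl also left, but a second change accompanied it, so the share of the methyl cannot be read from it. The steps of a 2.9-fold lower number from compound 1 to compound 2 (0.46 log units; beyond the scatter) and a 4.4-fold lower number from compound 2 to compound 3 (0.64 log units; beyond the scatter) bear on it only loosely. The analyst therefore expects for compound 4 a small rise in number, a 1.9-fold higher number from compound 3 to compound 4 (0.27 log units; within the scatter), possibly within the scatter. The estimate for compound 4 in this assay is 15000 nM, between 6000 nM and 40000 nM.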

Compound 4, half-maximal inhibitory concentration: 6260 nM
The estimate for compound 4 lay 2.4-fold (0.38 log units) above the measured number, within the range that was stated.
By their numbers in this assay, from the lowest: compounds 4 and 3 (each within the scatter of the next); then compound 2; then compound 1.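

In this assay, methyl in place of hydrogen on this saturated chain carbon gives a step within the scatter (a 1.3-fold lower number from compound 3 to compound 4 (0.11 log units; within the scatter)), so compound 3 and compound 4 cannot be told apart. Among these compounds, with the methyl present on both sides, 1-carbamoylethyl in place of (1-carbamoylethyl)amino still gives a large step (a 16-fold lower number from compound 1 to compound 4 (1.20 log units; beyond the scatter)), which the earlier compounds could not separate from the methyl. Replacing (2-carbamoylpyrrolidin-1-yl)methyl gives a modest step (a 5.6-fold lower number from compound 2 to compound 4 (0.75 log units; beyond the scatter)). Going by these compounds, whether an ethyl or longer chain on this carbon, or a carboxylic acid in place of the carbamoyl, would fare alike stays open. Nothing shown here gives a reason for these numbers.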